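Hydrogen in Place of Methyl on Compound 2

This account rests on a few compounds, and the source may have more. Where it says the series, first, only, none or still open, it means among the compounds named here.

Compound 1 `Cn1c(-c2cc(-c3ccccc3)no2)cc(Br)c1Br` and compound 2 `Cn1c(-c2cc(-c3ccccc3O)no2)cc(Br)c1Br` share one core and differ in a single place. In a functional assay on WRL68 cells (Homo sapiens) for cytotoxicity, read by MTT assay, with stated times of 6 h and 48 h (a higher number here means a weaker inhibitor, a lower number a stronger inhibitor), compound 1 gives >= 100000 nM, which is a limit of the assay and not a number. In this assay compound 2 gives >= 100000 nM, and this too is a limit. Both compounds therefore stand at the same point: the limit of >= 100000 nM in this assay, at which 2 of the 2 values shown sit. For the measured compounds named here, the one measured step is a step that the two limits leave unreadable from compound 1 to compound 2, with hydroxy in place of hydrogen on an aromatic carbon, and it offers no size to carry forward.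

Compound 3 `Oc1ccccc1-c1cc(-c2cc(Br)c(Br)[nH]2)on1` arises from compound 2 through a different change, (hydrogen in place of methyl on an aromatic nitrogen), hydrogen in place of methyl on an aromatic nitrogen. Going by the values given here, no measured step touches that nitrogen, so the data give no size for this change, and the only anchor is the limit of compound 2 at >= 100000 nM. No shift beyond the scatter is expected in this assay, in either direction, and another reading at the limit is the likeliest outcome. The estimated change is a number no higher from compound 2 to compound 3 (the limit leaves the size open). For compound 3 the expected value is 100000 nM, with an estimated range from 40000 nM to 200000 nM.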

Compound 3, half-maximal inhibitory concentration: >= 100000 nM
Compound 3 gave a limit, no number; the forecaster's own chance of this, stated with the estimate: 70%; the middle value lies on the limit itself.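

In this assay compound 3 gives >= 100000 nM, which is a limit and not a number. Compound 2 also stands at a limit, so no step can be read from compound 2 to compound 3. All three compounds stand together: the limit of >= 100000 nM in this assay, at which 3 of the 3 values shown sit. The compounds shown leave open whether hydroxy in place of hydrogen, or hydrogen in place of methyl, has any effect in this assay.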